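Nitro in place of acetamido: series notes

The source may hold more compounds than are shown below. What is called first, only, known or untested is meant among the compounds shown, and "the series" means these compounds.

In a functional assay on MDA-MB-231 cells (Homo sapiens) for inhibition, read by sulforhodamine B assay (on this read-out lower numbers stand for stronger inhibition of growth and higher numbers for weaker inhibition of growth), compound 1 `CC(=O)Nc1ccc(CN2CCC=C(CCC(=O)NO)C2=O)cc1` has no number, its entry reading "not determined" (no result reported). Among the compounds with values here, the only measured anchor is compound 2 `Cc1ccc(S(=O)(=O)Nc2ccc(CN3CCC=C(CCC(=O)NO)C3=O)cc2)cc1` at 560 nM. Compound 3 `O=C(CCC1=CCCN(Cc2ccc([N+](=O)[O-])cc2)C1=O)NO` departs from compound 1 by nitro in place of acetamido on an aromatic carbon, with nitro in place of acetamido on an aromatic carbon, para to a large group. Within the data shown here, no measured step covers this change. Measured against compound 2 at 560 nM, a step no larger than the usual scatter in this assay is expected, leaning toward weaker inhibition of growth. The estimated value for compound 3 is 900 nM, with an expected range of 280 nM to 2900 nM.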

Compound 3, concentration for 50% growth inhibition: 470 nM
The estimate for compound 3 lay 1.9-fold (0.28 log units) above the measured number, within the range that was stated.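

No new step can be read: compound 3 has a value, but compound 1 has no single number to set against it. Left open is what nitro in place of acetamido does to growth inhibition. No supporting measurement bears on this result.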